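Replacing 2,3-dimethylphenyl in compound 1

The source may hold more compounds than are shown below. What is called first, only, known or untested is meant among the compounds shown, and "the series" means these compounds.

Of the compounds shown here, two have been read so far in an ADME assay on microsomes from liver (Mus musculus) for metabolic stability, read by LC-MS, with a stated time of 1 h, tested at 5 uM; a higher number here means that more of the compound is left, a lower number that less of the compound is left. Compound 1 `Cc1nc(-c2ccccc2)c(C(=O)N2CCN(c3cccc(C)c3C)CC2)o1` gives 83.6%, the higher of the two numbers. Compound 2 `COc1cc(OC)cc(N2CCN(C(=O)c3oc(C)nc3-c3ccc(F)cc3)CC2)c1` gives 5.6%, a gap beyond the scatter. Compound 2 differs from compound 1 in more than one place, so this gap cannot be assigned to any single group.

The next compound is compound 3 `Cc1nc(-c2ccccc2)c(C(=O)N2CCN(c3cccc(C#N)c3)CC2)o1`, which has 3-cyanophenyl in place of 2,3-dimethylphenyl on an amine nitrogen in a ring. Among the measured compounds shown here, no measured pair isolates a change at this place, so the expectation rests on the two values alone and remains loose. Compound 1 at 83.6% leaves little room for a rise, while compound 2 at 5.6% shows that a member of the series can fall far lower in this assay. The expected step of a number 23.6 percentage points lower from compound 1 to compound 3 (beyond the scatter) is therefore downward and of moderate size, beyond the scatter. For compound 3 the estimated value is 60%, with an expected range of 30% to 85%.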

Compound 3, percent of the compound remaining: 1.6%
Compound 3: the middle estimate sits 58.4 percentage points above what was measured, outside the stated range (below it).
By their numbers in this assay, from the lowest: compounds 3 and 2 (each within the scatter of the next); then compound 1.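

In this assay, among the compounds shown here, the exchange of 2,3-dimethylphenyl for 3-cyanophenyl on the amine nitrogen in a ring gives a number 82 percentage points lower from compound 1 to compound 3 (beyond the scatter), the first step that isolates a single place. The high number of compound 1 is therefore not carried by the shared core alone: with that core unchanged, the group at this one position is enough to take the read-out from near the top of the measured numbers to near the bottom. Nothing available on these compounds bears on what lies behind this step, and the numbers record only its size and direction.

Going by these compounds, one step changes two things at once, so it remains open whether the drop goes with the arrival of the nitrile or with the departure of the dimethyl pattern. On the core of compound 1, a plain phenyl or a 3-methylphenyl at this place would help to separate those two readings, while a cyclohexyl group would test whether an aromatic ring is needed on that nitrogen at all.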